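This account rests on a few compounds, and the source may have more. Where it says the series, first, only, none or still open, it means among the compounds named here.

Measured so far:
Compound 1 `O=C1c2ccccc2O[C@@H](c2cccc(O)c2O)[C@@H]1O` — in a functional assay on RAW264.7 cells (Rattus norvegicus) for inhibition, with RAW264.7 (Mus musculus) as the target, read by Griess assay, with stated times of 2 h and 16 h (on this read-out lower numbers stand for stronger inhibition and higher numbers for weaker inhibition), compound 1 gives > 100000 nM.
Compound 2 `COc1ccc2c(c1)C(=O)[C@@H](O)[C@H](c1cccc(O)c1O)O2` — in this assay compound 2 gives > 100000 nM.
Compound 3 `COc1cc2c(cc1OC)C(=O)[C@H](O)[C@@H](c1cccc(O)c1O)O2` — in this assay compound 3 gives 50300 nM.

The value for compound 1 is a limit of the assay and not a number. The value for compound 2 is likewise a limit and not a number. Compound 3 is the only one of the three for which this assay returned a number at all, and that number sits at a high concentration.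

Compound 2 and compound 1 differ in one place: hydrogen in place of methoxy on an aromatic carbon. The step that the two limits leave unreadable from compound 2 to compound 1 cannot be read, because both values rest on a limit, as the limit of > 100000 nM in this assay, at which 2 of the 3 values shown sit, shows.

The fourth compound, compound 4 `COc1ccc2c(c1)O[C@H](c1cccc(O)c1O)[C@@H](O)C2=O`, has not been measured in this assay. It differs from compound 3 in one place: hydrogen in place of methoxy on an aromatic carbon. How compound 3 and compound 2 differ is not broken down here. The change from compound 3 to compound 4 is the same kind of change as that from compound 2 to compound 1, but not the same: in compound 4 the place is ortho to a methoxy group, which is not so for compound 1.

Compound 4 is expected to sit near the limit, with the step of a 2.2-fold higher number from compound 3 to compound 4 (0.34 log units; beyond the scatter), because compound 2, which also carries only one methoxy, gives > 100000 nM. The estimate for compound 4 in this assay is 110000 nM, between 40000 nM and 300000 nM.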

Compound 4, half-maximal inhibitory concentration: 24600 nM
Compound 4: middle estimate off by 4.5-fold (0.65 log units), on the high side; the measured number lies below the stated range.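

In this assay, putting hydrogen in place of methoxy on an aromatic carbon gives a 2.0-fold lower number from compound 3 to compound 4 (0.31 log units; beyond the scatter), a modest step but one that lies beyond the usual scatter. The same kind of change from compound 2 to compound 1 offers no second step for comparison, because both values are limits and that step cannot be read: the limit of > 100000 nM in this assay, at which 2 of the 4 values shown sit.

The step therefore shows what this change does in a single pair of compounds, where the place is ortho to a methoxy group, and it does not show whether the change would lower the number on the core of compound 1, where the place is not ortho to a methoxy group.

The compounds shown carry only methoxy or hydrogen at these aromatic places, so it remains open how an amine, a carboxylic acid or a longer chain such as ethoxy would behave there. Also open, from the compounds shown here alone, is whether any change at these places can bring the number far below the high concentrations seen so far, and how much the two hydroxy groups shared by all four compounds contribute to the inhibition.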